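A pyrimidine replaces the anisole on the amide of a quinoline ether

The source may report more compounds than this note shows. Statements on the series, on what has been measured and on what is new or still open speak of the compounds shown alone.

Of the compounds shown here, three that share a quinoline ether core have been measured in a toxicity assay on HepG2 cells (Homo sapiens) for inhibition, read by CellTiter-Glo, with a stated time of 48 h; a higher number here means a weaker inhibitor, a lower number a stronger inhibitor. Compound 1 `Cc1cc(C)cc(NC(=O)COc2cc(C)nc3ccc(F)cc23)c1` gives 63100 nM in this assay. For compound 2 `COc1ccc2nc(C(F)(F)F)cc(OCC(=O)Nc3cc(C)cc(C)c3)c2c1` only a limit of the assay is recorded, > 100000 nM. Compound 3 `COc1ccc2nc(C)cc(OCC(=O)Nc3cc(C)ccc3OC)c2c1` likewise returns only a limit, > 100000 nM, so that no number describes it and it stands at the limit of > 100000 nM in this assay, at which 2 of the 3 values shown sit. No pair among these three differs in a single place, so no measured step is available; the values show only that compound 1 returns a number while the other two do not.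

Compound 4 `COc1ccc2nc(C)cc(OCC(=O)Nc3cc(C)nc(C)n3)c2c1` has not yet been measured in this assay. It differs from compound 3 by one change: 2,6-dimethylpyrimidin-4-yl in place of 2-methoxy-5-methylphenyl on an amide-type nitrogen. Among the compounds with values here, the one measured number, from compound 1, lies close to the limit, and both other compounds sit at it, so the series is uniformly weak in this assay. The expected step of a number no higher from compound 3 to compound 4 (the limit leaves the size open) is none beyond the scatter. Compound 4 is therefore estimated to give 100000 nM in this assay, within a range from 30000 nM to 300000 nM, and most likely only another limit.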

Compound 4, half-maximal inhibitory concentration: > 100000 nM
Compound 4: no number, only a limit; the forecaster's own chance of this, stated with the estimate: 70%; the middle value lies on the limit itself.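

In this assay, compound 3 and compound 4 each return only a limit of the assay, so no step can be read between them: the limit of > 100000 nM in this assay, at which 3 of the 4 values shown sit. The compounds shown leave open whether 2,6-dimethylpyrimidin-4-yl and 2-methoxy-5-methylphenyl on an amide-type nitrogen differ at all in this assay.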